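Amide chain length at the anilide carbonyl

The source may report more compounds than this note shows. Statements on the series, on what has been measured and on what is new or still open speak of the compounds shown alone.

Measured so far in a functional assay on HCT-116 cells (Homo sapiens) for inhibition, read by MTT assay, with a stated time of 48 h; a lower number here means a stronger inhibitor, a higher number a weaker inhibitor:
compound 1, `C=C(C)C(=O)N(Cc1ccc(OC)c(O)c1)c1cc(OC)c(OC)c(OC)c1`, 200 nM
compound 2, `CCC/C=C/C(=O)N(Cc1ccc(OC)c(O)c1)c1cc(OC)c(OC)c(OC)c1`, 95 nM
compound 3, `C/C=C/C(=O)N(Cc1ccc(OC)c(C)c1)c1cc(OC)c(OC)c(OC)c1`, 23500 nM

Compound 2 gives the lowest number of the three measured compounds. Among the measured compounds shown here, compound 1 is its nearest neighbour, and the only measured step that touches compound 2 is a 2.1-fold lower number from compound 1 to compound 2 (0.32 log units; beyond the scatter), a modest change in favour of compound 2. Compound 3 lies far from compound 2, beyond the scatter, but it differs from compound 2 in two places, so its value alone says little about the carbonyl substituent.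

The next compound, compound 4, `C=CC(=O)N(Cc1ccc(OC)c(O)c1)c1cc(OC)c(OC)c(OC)c1`, differs from compound 2 only at the carbonyl carbon: vinyl in place of pent-1-en-1-yl on a carbonyl carbon. The change thus runs back along the same chain that the step from compound 1 to compound 2 extended, but further, to the shortest chain in the set. For the measured compounds named here, that step was modest in size, and no other measured pair isolates this position. A similarly modest step in the reverse direction is therefore the expectation, with the number for compound 4 rising somewhat above that of compound 2: a 2.3-fold higher number from compound 2 to compound 4 (0.36 log units; beyond the scatter) is the expected step. Compound 4 is estimated at 220 nM, with a range from 80 nM to 650 nM.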

Compound 4, half-maximal inhibitory concentration: 98 nM
Beside the measured number, compound 4's estimate is 2.2-fold (0.35 log units) above it; the measured number falls inside the stated range.
By their numbers in this assay, from the lowest: compounds 2 and 4 (each within the scatter of the next); then compound 1; then compound 3.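

In this assay the exchange of pent-1-en-1-yl for vinyl on the carbonyl carbon gives a 1.0-fold higher number from compound 2 to compound 4 (0.01 log units; within the scatter) and so, for these two compounds, going from 5 heavy atoms to 2 in the chain leaves the number within the scatter. Chain length alone therefore does not describe this position, and compound 1 goes against a flat reading of it: hydrogen in place of methyl on the double-bonded chain carbon bound to the carbonyl carbon gives a 2.0-fold lower number from compound 1 to compound 4 (0.31 log units; beyond the scatter) and this is a modest step, only just beyond the scatter. No evidence at hand bears on the reason for either step.

Still open, going by these compounds, is whether a longer chain than pent-1-en-1-yl, a saturated chain such as propyl, or a chain carrying an amine would stay in the same range, and whether the methyl step recurs when that methyl sits elsewhere on the chain. Compound 3 differs from compound 4 in two places, so it cannot separate the carbonyl substituent from the other change on the shared core.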